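Sulfonamide variation on a shared core: solubility notes

A few compounds are considered here, and "the series" means these few. Any claim that something is new, unique, unknown or untested is made for them only; others in the source may bear on it.

Measured so far:
compound 1 `O=S(=O)(c1cccc(-c2ccc3nccc(-c4ccncc4)c3n2)c1)N1CCC(O)CC1`: 10000 nM
compound 2 `O=S(=O)(c1cccc(Nc2ccc3nccc(-c4ccncc4)c3n2)c1)N1CCCC1`: < 5000 nM

Two compounds of the series have been run in a physicochemical assay for solubility, read by HPLC, using the shake flask method, measured as kinetic solubility, with a stated time of 20 h, at pH 6.5, tested at 200 uM; a lower number here means a less soluble compound, a higher number a more soluble compound. Compound 1 `O=S(=O)(c1cccc(-c2ccc3nccc(-c4ccncc4)c3n2)c1)N1CCC(O)CC1` gives 10000 nM. For compound 2 `O=S(=O)(c1cccc(Nc2ccc3nccc(-c4ccncc4)c3n2)c1)N1CCCC1` the result is only a limit of the assay, < 5000 nM, and no number. The two values therefore show compound 1 with a measured figure and compound 2 sitting at the limit of < 5000 nM in this assay, at which 1 of the 2 values shown sits; compound 1 and compound 2 differ in more than one place, so nothing is said here about any single change between them.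

The next compound, compound 3 `O=S(=O)(NCc1ccccc1)c1cccc(Nc2ccc3nccc(-c4ccncc4)c3n2)c1`, changes compound 2 at one place: benzylamino in place of pyrrolidin-1-yl on a sulfonyl sulfur.

Within the data shown here, no step between measured compounds is available for this change. Starting from a compound already at the limit, the step from compound 2 to compound 3 is expected to be a step that the limit leaves unreadable from compound 2 to compound 3, that is, nothing beyond the scatter in this assay, and the result for compound 3 may again be a limit. For compound 3 the expected value is 3000 nM, within a range from 1000 nM to 8000 nM.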

Compound 3, solubility: < 5000 nM
Compound 3 was reported as a limit (the forecaster's own chance of this, stated with the estimate: 70%); the middle value is on the limit's open side.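

No step from compound 2 to compound 3 can be read in this assay, because both results are limits and not numbers: the limit of < 5000 nM in this assay, at which 2 of the 3 values shown sit.

The compounds shown leave open whether benzylamino in place of pyrrolidin-1-yl on a sulfonyl sulfur shifts solubility at all, and if so, in which direction and by how much.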